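Shortening the acyl chain on a weakly cytotoxic pyranone

A few compounds are considered here, and "the series" means these few. Any claim that something is new, unique, unknown or untested is made for them only; others in the source may bear on it.

Measured compounds:
- compound 1, `CCCCCCCCCCCCCC(=O)c1c(O)cc(C)oc1=O`: > 200000 nM
- compound 2, `CCCCCCc1c(O)cc(C)oc1=O`: > 200000 nM
- compound 3, `CCCCCCCCCCc1c(O)cc(C)oc1=O`: 56000 nM

All three compounds share one core and differ only in the chain attached to it. In an ADME assay on L929 cells (Mus musculus, culture collection number NCTC 929) for cytotoxicity, read by MTT assay, with a stated time of 72 h (on this read-out higher numbers stand for weaker inhibition and lower numbers for stronger inhibition), compound 1 reaches only a limit of the assay, > 200000 nM, so no number is known for it. Compound 2 likewise gives only a limit, > 200000 nM. Compound 3 gives a number, 56000 nM. For the measured compounds named here, the one step that can be sized here is an at least 3.5-fold lower number from compound 2 to compound 3 (0.55 log units; beyond the scatter), a chain lengthening that lowered the number. Two of the three values sit at the limit of > 200000 nM in this assay, at which 2 of the 3 values shown sit, so compound 1 stands among the weakest inhibitors shown, with nothing below it to compare against.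

Compound 4, `CCCCCCCC(=O)c1c(O)cc(C)oc1=O`, has not yet been measured. It differs from compound 1 by hydrogen in place of hexyl on a saturated chain carbon, seven bonds along the chain from a carbonyl carbon. This is a chain shortening, the reverse direction of the lengthening seen from compound 2 to compound 3, which made inhibition stronger; a shortening is therefore not expected to make it stronger, and compound 1 already sits at the limit. Compound 4 is expected to remain very weak in this assay, with the step from compound 1 estimated as a number no higher from compound 1 to compound 4 (the limit leaves the size open). The estimate for compound 4 is 200000 nM, expected between 80000 nM and 500000 nM, most likely reported only as a limit.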

Compound 4, half-maximal inhibitory concentration: 140000 nM
Beside the measured number, compound 4's estimate is 1.4-fold (0.15 log units) above it, and the stated range covers the measured number.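

In this assay compound 4 gives 140000 nM, a real number, so hydrogen in place of hexyl at this place on the chain, seven bonds along from a carbonyl carbon, brings a chain joined through a carbonyl inside the measurable range. The change reads as an at least 1.4-fold lower number from compound 1 to compound 4 (0.15 log units; that floor lies within the scatter), so the shortening did not raise the number, yet it cannot be said to have strengthened inhibition, and this sits apart from the lengthening that gave an at least 3.5-fold lower number from compound 2 to compound 3 (0.55 log units; beyond the scatter), so chain length does not act in one simple direction across these two pairs. The true size of the step stays unknown because compound 1 gives only a limit of the assay, not a number: the limit of > 200000 nM in this assay, at which 2 of the 4 values shown sit.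

The compounds shown leave open how the number moves at chain lengths between those of compound 4 and compound 1, and whether a still shorter chain such as butyryl would keep it measurable. They also leave open what an amine or a carboxylic acid on the chain would do to the number.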